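Chlorophenyl urea position shift in a cytotoxicity series

A few compounds are considered here, and "the series" means these few. Any claim that something is new, unique, unknown or untested is made for them only; others in the source may bear on it.

Measured so far:
compound 1, `CCN(CC)CCCNc1nc(-c2ccc(NC(=O)Nc3ccc(Cl)cc3)cc2)nc2c(Cl)c(Cl)sc12`: 720 nM
compound 2, `CCN(CC)CCCNc1nc(-c2ccc(NC(=O)Nc3ccccc3Cl)cc2)nc2c(Cl)c(Cl)sc12`: 1450 nM
compound 3, `CCN(CC)CCNc1nc(-c2ccc(NC(=O)Nc3ccc(Cl)cc3)cc2)nc2c(Cl)c(Cl)sc12`: 890 nM

All three were read in a functional assay on MKN-45 cells (Homo sapiens) for cytotoxicity, read by MTT assay, with a stated time of 72 h; on this read-out lower numbers stand for stronger inhibition and higher numbers for weaker inhibition. Compound 1 gives 720 nM in this assay, compound 2 gives 1450 nM and compound 3 gives 890 nM.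

Two changes are covered. The first, (2-chlorophenyl in place of 4-chlorophenyl on an amide-type nitrogen), moves the chlorine on the urea-bearing ring and gives a 2.0-fold higher number from compound 1 to compound 2 (0.30 log units; within the scatter). The second, (diethylamino in place of (diethylamino)methyl on a saturated chain carbon, two bonds along the chain from a nitrogen on an aromatic ring), shortens the amine-bearing chain and gives a 1.2-fold higher number from compound 1 to compound 3 (0.09 log units; within the scatter). Both steps sit within the scatter, so no ordering among compounds 1, 2 and 3 is claimed.

Compound 4, `CCN(CC)CCNc1nc(-c2ccc(NC(=O)Nc3ccccc3Cl)cc2)nc2c(Cl)c(Cl)sc12`, has not been measured. Among the compounds with values here, it differs from compound 3 by 2-chlorophenyl in place of 4-chlorophenyl on an amide-type nitrogen, the same change as the one between compound 1 and compound 2, made on the core of compound 3 rather than that of compound 1; the two cores differ by diethylamino in place of (diethylamino)methyl on a saturated chain carbon, two bonds along the chain from a nitrogen on an aromatic ring.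

Within the data shown here, for compound 4 the expected step is a 2.0-fold higher number from compound 3 to compound 4 (0.31 log units; beyond the scatter), taken to match the earlier one because a 2.0-fold higher number from compound 1 to compound 2 (0.30 log units; within the scatter) is the only measurement of this change, and the chain difference gave a step of only a 1.2-fold higher number from compound 1 to compound 3 (0.09 log units; within the scatter). Compound 4 is estimated at 1800 nM, with a likely range from 1000 nM to 3400 nM.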

Compound 4, half-maximal inhibitory concentration: 1130 nM
The estimate for compound 4 lay 1.6-fold (0.20 log units) above the measured number, within the range that was stated.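

Moving the chlorine from 4-chlorophenyl to 2-chlorophenyl on the core of compound 3 gives a 1.3-fold higher number from compound 3 to compound 4 (0.10 log units; within the scatter) in this assay, and this step cannot be told apart from the one on the core of compound 1: the same change on two cores in this assay, a 2.0-fold higher number (0.30 log units; within the scatter) from compound 1 to compound 2 and a 1.3-fold higher number (0.10 log units; within the scatter) from compound 3 to compound 4, 1.6-fold (0.20 log units) apart, within the scatter of two such steps

The chain change, read on the 2-chlorophenyl pair, gives a 1.3-fold lower number from compound 2 to compound 4 (0.11 log units; within the scatter), and its two readings cannot be told apart either: the same change on two cores in this assay, a 1.2-fold higher number (0.09 log units; within the scatter) from compound 1 to compound 3 and a 1.3-fold lower number (0.11 log units; within the scatter) from compound 2 to compound 4, 1.6-fold (0.20 log units) apart, within the scatter of two such steps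

Within these four compounds, then, the chlorine shift carries from one core to the other with no detectable difference, but this is only a lack of resolved difference on two cores, not proof that the steps are equal, and with every step inside the scatter it does not show that either change alters the read-out on any core.

The compounds shown leave open how the urea end would read with a plain phenyl or a 4-fluorophenyl in place of the chlorophenyl groups, and how the amine end would read with a longer chain or a morpholine in place of the diethylamino group. Going by these compounds, whether the same small steps would hold on any other cell line also stays open.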